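A few compounds are considered here, and "the series" means these few. Any claim that something is new, unique, unknown or untested is made for them only; others in the source may bear on it.

Compound 1 `COc1ccc(N2CCN(Cn3nc(-c4ccc5c(c4)OCCO5)oc3=S)CC2)cc1` is one of a small set built on a shared core. In a functional assay on HepG2 cells (Homo sapiens) for antiproliferative activity, read by MTT assay, with a stated time of 48 h (a higher number here means a weaker inhibitor, a lower number a stronger inhibitor), compound 1 gives > 50000 nM, which is a limit of the assay rather than a number. Compound 2 `Fc1ccc(N2CCN(Cn3nc(-c4ccc5c(c4)OCCO5)oc3=S)CC2)cc1` also reaches only a limit, giving > 50000 nM. Compound 3 `S=c1oc(-c2ccc3c(c2)OCCO3)nn1CN1CCN(c2ccccn2)CC1` gives 11400 nM. Compound 1 therefore stands at the limit; the step that the two limits leave unreadable from compound 1 to compound 2 cannot be read, while an at least 4.3-fold lower number from compound 1 to compound 3 (0.64 log units; beyond the scatter) and an at least 4.3-fold lower number from compound 2 to compound 3 (0.64 log units; beyond the scatter) show that pyridin-2-yl on the ring nitrogen brings the number down. Compound 4 `O=[N+]([O-])c1ccc(N2CCN(Cn3nc(-c4ccc5c(c4)OCCO5)oc3=S)CC2)cc1` differs from compound 1 only by nitro in place of methoxy on an aromatic carbon. Within the data shown here, no measured step alters this group in a readable way; the only bearing comes from the limit of > 50000 nM in this assay, at which 2 of the 3 values shown sit, where compounds 1 and 2 both sit. With nothing measured pointing toward a lower number, compound 4 is expected near 60000 nM, within a range from 20000 nM to 150000 nM. That estimate means a step that the limit leaves unreadable from compound 1 to compound 4, none beyond the scatter, and it is expected that only a limit will again be reported.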

Compound 4, half-maximal inhibitory concentration: 29500 nM
Compound 4: middle estimate off by 2.0-fold (0.31 log units), on the high side; measured number inside the range.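

Among the compounds shown with a substituted phenyl group on this ring nitrogen, compound 4 alone gives a real number in this assay rather than a limit. Placing nitro where methoxy stood gives an at least 1.6-fold lower number from compound 1 to compound 4 (0.22 log units; that floor lies within the scatter), and placing it where fluoro stood gives an at least 1.6-fold lower number from compound 2 to compound 4 (0.22 log units; that floor lies within the scatter); these are only floors, because compound 1 and compound 2 each stay at a limit: the limit of > 50000 nM in this assay, at which 2 of the 4 values shown sit. The pyridin-2-yl group still holds the lowest number of the set, as the change to 4-nitrophenyl gives a 2.6-fold higher number from compound 3 to compound 4 (0.41 log units; beyond the scatter).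

Going by these compounds, the true size of the change from methoxy or fluoro to nitro stays open, since neither starting compound has a number of its own. Also open, on these data alone, is how an amine or a carboxylic acid would read at this same place, on the aromatic carbon para to a large group.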